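The source may report more compounds than this note shows. Statements on the series, on what has been measured and on what is new or still open speak of the compounds shown alone.

Compound 1, `CCOC(=O)c1cnn(-c2nc(-c3ccccc3O)c(C#N)c(=O)n2C)c1N`, is measured in a functional assay, with a stated time of 10 min (on this read-out higher numbers stand for weaker inhibition and lower numbers for stronger inhibition), where compound 1 gives 58 ug/mL. That is the highest of the three numbers at hand, but the other two sit within the usual scatter of it: compound 2, `Cn1c(NN)nc(-c2ccccc2F)c(C#N)c1=O`, gives 49 ug/mL, and compound 3, `Cn1c(NN)nc(-c2ccccc2Cl)c(C#N)c1=O`, gives 46 ug/mL. Among the measured compounds shown here, the one measured step, a 1.1-fold lower number from compound 2 to compound 3 (0.03 log units; within the scatter), is a change the assay cannot tell apart from repeat noise.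

Compound 4, `CCOC(=O)c1cnn(-c2nc(-c3cccc(OC)c3OC)c(C#N)c(=O)n2C)c1N`, differs from compound 1 in one place: 2,3-dimethoxyphenyl in place of 2-hydroxyphenyl on an aromatic carbon. For the measured compounds named here, no measured pair replaces a 2-hydroxyphenyl with a 2,3-dimethoxyphenyl, and compounds 2 and 3 carry a different group on the shared core, so only the general lesson of that single step applies: a small change on the aromatic ring left the number essentially where it was. The expectation for compound 4 is therefore no step beyond the scatter, a 1.1-fold lower number from compound 1 to compound 4 (0.02 log units; within the scatter). Compound 4 is estimated to give 55 ug/mL, with a range from 25 ug/mL to 120 ug/mL.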

Compound 4, half-maximal inhibitory concentration: 67 ug/mL
Estimate against measurement, compound 4: 1.2-fold (0.09 log units) below; the measured number falls inside the stated range.
By their numbers in this assay, from the lowest: compounds 3, 2, 1 and 4 (each within the scatter of the next).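

Compound 1 and compound 4 differ only in the group on an aromatic carbon of the shared core, and in this assay that swap gives a 1.2-fold higher number from compound 1 to compound 4 (0.06 log units; within the scatter) even though it is much larger than the earlier exchange of one halogen for another. The entering 2,3-dimethoxyphenyl has 10 heavy atoms against 7 and 0 hydrogen-bond donors against 1, so in this pair neither the added bulk of atoms nor the loss of the hydroxyl hydrogen moves the number beyond the scatter. No supporting measurement is available to explain this result.

Still open is whether any group at this place can move the number beyond the scatter, since every step shown stays within it. A phenyl ring carrying an amine or a carboxylic acid would test this with a different kind of substituent.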